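Removing the Chloro Group from a Bis(trifluoromethyl) Sulfonamide

A few compounds are considered here, and "the series" means these few. Any claim that something is new, unique, unknown or untested is made for them only; others in the source may bear on it.

Compound 1 `O=S(=O)(NCCCNCc1ccccc1Cl)c1cc(C(F)(F)F)cc(C(F)(F)F)c1` was tested in a functional assay on MIA PaCa-2 cells (Homo sapiens) for inhibition, read by MTT assay, with a stated time of 72 h (a lower number here means a stronger inhibitor of growth, a higher number a weaker inhibitor of growth), and compound 1 gives 11000 nM. Compound 2 `O=S(=O)(NCCCCCCNCc1ccc(Br)cc1)c1ccc2c(c1)OCC2`, measured in this assay, gives 13000 nM. Compound 1 stands at the low end of these two numbers, but its gap to compound 2 lies within the scatter of repeated measurements, so the two values show no difference that can be read. Among the measured compounds shown here, no step between two measured compounds differing in a single place is available. The unmeasured compound 3 `O=S(=O)(NCCCNCc1ccccc1)c1cc(C(F)(F)F)cc(C(F)(F)F)c1` differs from compound 1 in one place: hydrogen in place of chloro on an aromatic carbon. For the measured compounds named here, with no single-point step to lean on, the effect of this change in this assay is expected to be small, a step of a 1.4-fold higher number from compound 1 to compound 3 (0.13 log units; within the scatter) that stays within the scatter. Compound 3 is therefore estimated at 15000 nM in this assay, with a range from 7000 nM to 35000 nM.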

Compound 3, concentration for 50% growth inhibition: 11000 nM
Compound 3: middle estimate off by 1.4-fold (0.13 log units), on the high side, and the stated range covers the measured number.
By their numbers in this assay, from the lowest: compounds 1, 3 and 2 (each within the scatter of the next).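

Hydrogen in place of chloro gives no change at the digits printed from compound 1 to compound 3 (within the scatter) in this assay, the first comparison here in which only one place differs. At this aromatic carbon, ortho to a large group, going from 2-chlorobenzyl to benzyl therefore leaves growth inhibition unchanged within the scatter, something the comparison of compound 1 with compound 2, which differ in more than one place, could not show. Nothing measured here accounts for this result.

The compounds shown leave open whether a different group at this carbon, such as methoxy, an amine or a carboxylic acid, would shift the number in this assay. They also leave open whether the same exchange of chloro for hydrogen would read the same on a longer chain.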